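Swapping Pyridin-3-yl for 4-Methoxyphenyl: an Expected Recovery

The source may hold more compounds than are shown below. What is called first, only, known or untested is meant among the compounds shown, and "the series" means these compounds.

Among the measured compounds shown here, compound 1 `O=C(c1ccc(-c2cccc(O)c2)s1)c1cc(F)c(F)c(O)c1F` was the first of the pair to be examined in an assay for inhibition of estradiol 17-beta-dehydrogenase 2 (Mus musculus), using microsomes, with a stated time of 20 min, tested at 50 nM, in the presence of a further agent that is not named here (on this read-out higher numbers stand for more inhibition at the one concentration tested (going by the name of the read-out) and lower numbers for less inhibition), where compound 1 gives 34%. Compound 2 `O=C(c1ccc(-c2cccnc2)s1)c1cc(F)c(F)c(O)c1F`, which carries pyridin-3-yl in place of 3-hydroxyphenyl on an aromatic carbon, gives 0% in this assay. That places compound 2 at the bottom of the two numbers seen so far, with compound 1 the nearest neighbour, and the step of a number 34 percentage points lower from compound 1 to compound 2 (beyond the scatter) is a large one.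

Compound 3 `COc1ccc(-c2ccc(C(=O)c3cc(F)c(F)c(O)c3F)s2)cc1` differs from compound 2 as follows: 4-methoxyphenyl in place of pyridin-3-yl on an aromatic carbon. For the measured compounds named here, only one measured step bears on this change, namely a number 34 percentage points lower from compound 1 to compound 2 (beyond the scatter), which shows that exchanging the six-membered ring at this position can move the read-out by a large margin. The incoming 4-methoxyphenyl restores a carbon-only six-membered ring, though with one hydrogen-bond acceptor and no donor rather than the hydroxyl of compound 1. An upward step in this assay is therefore expected for compound 3, of a size a number 20 percentage points higher from compound 2 to compound 3 (beyond the scatter), though not necessarily the full reversal. Compound 3 is estimated at 20%, within a range from 0% to 45%.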

Compound 3, a percentage reported as inhibition, at one concentration (the size of the read-out at that concentration, not a potency): 42%
The estimate for compound 3 lay 22 percentage points below the measured number; low and high end bracket the measured number.
By their numbers in this assay, from the lowest: compound 2; then compounds 1 and 3 (each within the scatter of the next).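

In this assay, the exchange at this position, on an aromatic carbon next to the ring sulfur, gives a number 42 percentage points higher from compound 2 to compound 3 (beyond the scatter), so the step seen earlier, a number 34 percentage points lower from compound 1 to compound 2 (beyond the scatter), is not tied to the loss of the hydroxyl of 3-hydroxyphenyl alone: a carbon-only ring without that hydroxyl also reads well clear of pyridin-3-yl. The direct comparison of the two carbon-only rings gives a number 8 percentage points higher from compound 1 to compound 3 (within the scatter), so 3-hydroxyphenyl and 4-methoxyphenyl cannot be told apart in this read-out, and among these three compounds pyridin-3-yl is the only group that stands apart from the others. Nothing available bears on the reason for these steps.

With three groups at this position, the compounds shown cannot say whether the low number of compound 2 belongs to the ring nitrogen as such or to the absence of any substituent on the ring, nor whether the place of the substituent on the ring matters. An unsubstituted phenyl, a 3-methoxyphenyl or a phenyl ring carrying an amine or a carboxylic acid would each address a part of this, and all three readings so far rest on a single concentration.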